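Benzyl Carbamate Variant of a Thiazolidinedione Agonist Series

The source may hold more compounds than are shown below. What is called first, only, known or untested is meant among the compounds shown, and "the series" means these compounds.

Compound 1 `Cc1c(Oc2ccc(/C=C3\SC(=O)NC3=O)cc2)ncnc1OC1CCN(C(=O)OCC(C)C)CC1`: 70.2%
Compound 2 `CCOC(=O)N1CCC(Oc2cc(Oc3ccc(/C=C4\SC(=O)NC4=O)cc3)ncn2)CC1`: 51.8%
Compound 3 `CCOC(=O)N1CCC(Oc2cc(Oc3cccc(/C=C4\SC(=O)NC4=O)c3)ncn2)CC1`: 43.3%

In a functional assay on CHO-K1 cells for agonist activity at Glucose-dependent insulinotropic receptor (Homo sapiens), read by cAMP accumulation and immunoassay, with a stated time of 1 h (a higher number here means a larger maximal response, a lower number a smaller maximal response), compound 3 gives 43.3%, the lowest of the three numbers. Compound 2 sits within the usual scatter of it, so the two cannot be told apart, while compound 1 lies beyond the scatter above compound 3. Compound 4 `O=C1NC(=O)/C(=C/c2cccc(Oc3cc(OC4CCN(C(=O)OCc5ccccc5)CC4)ncn3)c2)S1` differs from compound 3 in one place: phenyl in place of methyl on a saturated chain carbon bound to an oxygen next to a carbonyl group. Within the data shown here, no measured pair isolates this change, so its effect is not known from the data. Among the measured compounds shown here, since compound 1, the only compound with a larger group at this position, shows the highest maximal response, the step of a number 6.7 percentage points higher from compound 3 to compound 4 (within the scatter) is expected to be small and upward, not clearly beyond the scatter. Compound 4 is therefore estimated at 50%, with a range from 30% to 70%.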

Compound 4, largest response reached (Emax), in percent of the reference or control that the assay uses: 98.3%
Compound 4: the middle estimate sits 48.3 percentage points below what was measured; the measured number lies above the stated range.
By their numbers in this assay, from the lowest: compounds 3 and 2 (each within the scatter of the next); then compound 1; then compound 4.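

In this assay, among these compounds, phenyl in place of methyl on a saturated chain carbon bound to an oxygen next to a carbonyl group gives a large rise in maximal response (a number 55 percentage points higher from compound 3 to compound 4 (beyond the scatter)), so this position, which no earlier measured pair had isolated, strongly affects the read-out. No measured evidence accounts for the rise.

On these data alone, whether it takes an aromatic ring here stays open, since cyclohexyl, pyridyl or a longer chain such as butyl at this carbon would separate ring from size. As far as these compounds go, whether ethoxycarbonyl to benzyloxycarbonyl acts alike on the core of compound 2 also stays open.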